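Removing a Chloro Group: Compound 3 to Compound 4

A few compounds are considered here, and "the series" means these few. Any claim that something is new, unique, unknown or untested is made for them only; others in the source may bear on it.

In a functional assay on the whole organism (strain Swiss) with Mus musculus as the target, in the maximal electroshock model, with a stated time of 1 h, at a dose of 300 mg/kg by the intraperitoneal route (on this read-out higher numbers stand for a stronger effect at the one dose given and lower numbers for a weaker effect), three compounds have been measured:

compound 1, `CC(C(=O)N1CCN(c2ccccc2)CC1)N1C(=O)CCC1=O`: 50%
compound 2, `CC(C(=O)N1CCN(c2ccccc2Cl)CC1)N1C(=O)CCC1=O`: 25%
compound 3, `CCC(C(=O)N1CCN(c2ccc(Cl)cc2)CC1)N1C(=O)CCC1=O`: 25%

Compound 1 and compound 2 differ by hydrogen in place of chloro on an aromatic carbon, and in this assay this change gives a number 25 percentage points higher from compound 2 to compound 1 (beyond the scatter). Compound 3 and compound 2 stand level in this assay; how their two cores differ is not broken down here.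

Compound 4, `CCC(C(=O)N1CCN(c2ccccc2)CC1)N1C(=O)CCC1=O`, is not yet measured. It differs from compound 3 by hydrogen in place of chloro on an aromatic carbon. This is the same kind of change as that from compound 2 to compound 1, but not the same: there the chloro stood ortho to a large group, here it stands para to a large group.

Resting on the single earlier step, a number 25 percentage points higher from compound 2 to compound 1 (beyond the scatter), compound 4 is expected to show a number 20 percentage points higher from compound 3 to compound 4 (beyond the scatter) in this assay. The estimate for compound 4 is 45%, between 20% and 70%.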

Compound 4, a percentage reported as activity, at one dose (the size of the read-out at that dose, not a potency): 75%
The estimate for compound 4 lay 30 percentage points below the measured number, outside the stated range (above it).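

In this assay, hydrogen in place of chloro again gives a higher number, a number 50 percentage points higher from compound 3 to compound 4 (beyond the scatter), so the direction of the change holds on both cores, but its size does not: the same change on two cores in this assay, a number 25 percentage points higher (beyond the scatter) from compound 2 to compound 1 and a number 50 percentage points higher (beyond the scatter) from compound 3 to compound 4, 25 percentage points apart, beyond the scatter of two such steps

The two steps differ both in the core and in where the chloro stands, so these compounds cannot show which of the two sets the size, and two steps make no rule for other cores. Without any chloro, methyl in place of hydrogen on the saturated chain carbon gives a number 25 percentage points higher from compound 1 to compound 4 (beyond the scatter).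

Going by these compounds, it remains open whether a fluoro or methoxy group on the phenyl would match the number of compound 4. On these data alone, whether a longer chain on that saturated carbon would raise the number further also remains open.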